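The source may hold more compounds than are shown below. What is called first, only, known or untested is meant among the compounds shown, and "the series" means these compounds.

Three compounds have been measured in an assay on CHO cells for antagonist activity at transient receptor potential cation channel subfamily V member 1 (Homo sapiens), read by FLIPR and calcium flux; a higher number here means a weaker inhibitor, a lower number a stronger inhibitor:

Compound 1, `CCCCCc1nc(C(F)(F)F)ccc1CNC(=O)C(C)c1ccc(NS(C)(=O)=O)c(F)c1`: 1 nM
Compound 2, `CC(C(=O)NCc1ccc(C(F)(F)F)nc1C1CCC(C)(C)CC1)c1ccc(NS(C)(=O)=O)c(F)c1`: 0.4 nM
Compound 3, `CC(C(=O)NCc1ccc(C(F)(F)F)nc1C1=CCCCC1)c1ccc(NS(C)(=O)=O)c(F)c1`: 0.7 nM

All three share one core and differ only in the group on an aromatic carbon of it. Compound 3 holds the second highest of the three numbers, but the gaps around it are small: the step of a 1.4-fold lower number from compound 1 to compound 3 (0.15 log units; within the scatter) and the step of a 1.8-fold higher number from compound 2 to compound 3 (0.24 log units; within the scatter) both fall within the scatter, so no real order among these compounds can be claimed. Within the data shown here, the only step that reaches beyond the scatter is a 2.5-fold lower number from compound 1 to compound 2 (0.40 log units; beyond the scatter), a modest one.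

Compound 4, `CC1C=C(c2nc(C(F)(F)F)ccc2CNC(=O)C(C)c2ccc(NS(C)(=O)=O)c(F)c2)CCC1`, differs from compound 3 by methyl in place of hydrogen on a saturated ring carbon. Among the measured compounds shown here, every measured step swaps the whole group on that aromatic carbon; none adds a single methyl to a ring that is already there, so no step speaks to this change directly. The three measured numbers lie close together, and the change is small, so for this assay no step beyond the scatter is expected: the estimated step is no change at the digits printed from compound 3 to compound 4 (within the scatter). Compound 4 is therefore expected to give 0.7 nM, with a range from 0.3 nM to 1.6 nM.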

Compound 4, inhibition constant: 0.2 nM
The estimate for compound 4 lay 3.5-fold (0.54 log units) above the measured number; measured number below the stated range.
By their numbers in this assay, from the lowest: compounds 4, 2, 3 and 1 (each within the scatter of the next, the first and the last beyond it).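

In this assay a single methyl on a saturated ring carbon, two ring bonds from the ring atom that bears a large group, gives a 3.5-fold lower number from compound 3 to compound 4 (0.54 log units; beyond the scatter) and so shows that this ring position responds to one added carbon, something the earlier swaps of the whole group could not show. The new 3-methylcyclohex-1-en-1-yl group also stands apart from pentyl with a 5.0-fold lower number from compound 1 to compound 4 (0.70 log units; beyond the scatter) but not from 4,4-dimethylcyclohexyl with a 2.0-fold lower number from compound 2 to compound 4 (0.30 log units; within the scatter) and so no order can be claimed between those last two groups. Nothing shown here accounts for the effect of the methyl.

From the compounds shown here alone, whether an ethyl, a hydroxyl or a fluorine on this ring carbon would act like the methyl remains open. So does whether a second methyl on that same carbon would add to the step.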